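A Hydroxyl Replaces an Amine in a Cytotoxicity Series

The source may hold more compounds than are shown below. What is called first, only, known or untested is meant among the compounds shown, and "the series" means these compounds.

Three compounds have so far been examined in an ADME assay on BJ cells (Homo sapiens) for cytotoxicity, read by CellTiter-Glo and resazurin assay, with a stated time of 72 h; a higher number here means that more compound is needed for the effect, a lower number that less compound is needed. Compound 1 `CC(C)N(Cc1cccc(OCCCCCC(=O)O)c1)C(=O)c1ccccc1` reports > 26000 nM, which is a limit of the assay rather than a number. Compound 2 `CCOC(=O)CCCCCOc1cccc(CN(C(=O)c2ccc(-c3cnc(OC)nc3OC)cc2)C(C)C)c1` likewise reaches only a limit, > 26000 nM. Compound 3 `CCOC(=O)CCCCCOc1ccc(CNC(C)C)cc1` also gives only a limit, > 26000 nM. Given (the limit of > 26000 nM in this assay, at which 3 of the 3 values shown sit), compound 3 stands nowhere apart from its companions in this assay. Compound 4 `CCOC(=O)CCCCCOc1ccc(CO)cc1` differs from compound 3 by hydroxy in place of isopropylamino on a saturated chain carbon bound to an aromatic carbon. For the measured compounds named here, no measured step guides this change, so nothing beyond the usual scatter is expected in this assay. Compound 4 is therefore estimated at 30000 nM, within 20000 nM to 60000 nM. The step that the limit leaves unreadable from compound 3 to compound 4 is expected to be none beyond scatter.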

Compound 4, half-maximal effective concentration: > 27100 nM
Compound 4: no number, only a limit; the forecaster's own chance of this, stated with the estimate: 90%; the middle value lies beyond the limit too.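

For the compounds shown here, compound 3 and compound 4 both reach only limits in this assay, so no step between them can be read. The compounds shown leave open what concentration would produce the effect for any of them, and whether hydroxy in place of isopropylamino alters it.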